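The source may hold more compounds than are shown below. What is called first, only, known or untested is meant among the compounds shown, and "the series" means these compounds.

Within the data shown here, compound 1, with the structure `CCCCCCCCCCCCCCCCc1nc(N2CCC2)c(C)c(C)c1O`, is one of two compounds measured so far in a functional assay on cells (Lymphocyte), read by a luciferase reporter and ATP content, with a stated time of 48 h, tested at 25 uM; on this read-out lower numbers stand for a stronger effect and higher numbers for a weaker effect at the one concentration tested. In this assay compound 1 gives 38%, the lower of the two numbers. Its nearest neighbour, compound 2, with the structure `CCCCCCCCCCCCCCCCc1c(C)c(N2CCC2)nc(C)c1O`, gives 50% in this assay, a gap that lies beyond the usual scatter of repeated measurements. Compound 3, with the structure `CCCCCCCCCCCCCCCCc1nc(N(C)C)c(C)c(C)c1O`, has not yet been measured in this assay. It differs from compound 1 in one place: dimethylamino in place of azetidin-1-yl on an aromatic carbon. Among the measured compounds shown here, no pair of measured compounds shows a step of this kind, so there is nothing to lean on except the size of the groups. The change is small, and the expectation is for a small step, if any, toward a weaker effect, with a higher number. For compound 3 the estimated value in this assay is 45%, within a range from 30% to 62%, which means an expected step of a number 7 percentage points higher from compound 1 to compound 3 (within the scatter).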

Compound 3, a percentage reported as activity, at one concentration (the size of the read-out at that concentration, not a potency): 41%
Compound 3: the middle estimate sits 4 percentage points above what was measured; the range from low to high includes it.
By their numbers in this assay, from the lowest: compounds 1, 3 and 2 (each within the scatter of the next, the first and the last beyond it).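

In this assay, dimethylamino in place of azetidin-1-yl on this aromatic carbon, para to the hydroxy group, gives a number 3 percentage points higher from compound 1 to compound 3 (within the scatter). The earlier compounds shown here both carried azetidin-1-yl, whereas compound 3 shows that a group with no ring can stand at this position without a step beyond the scatter, so the four-membered ring is not required for the read-out at the one concentration tested. No measurement at hand explains why the two groups read alike.

From the compounds shown here alone, whether the same holds for larger rings on this carbon, such as piperidin-1-yl or morpholin-4-yl, remains open. So does the outcome with a plain amino group or a methylamino group here, which would show how much of the dimethylamino group this position needs.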